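A few compounds are considered here, and "the series" means these few. Any claim that something is new, unique, unknown or untested is made for them only; others in the source may bear on it.

Compound 1 `C[C@@H](O)[C@H]1C(=O)N2C(C(=O)OCC(F)(F)F)=C(S[C@@H]3CN[C@H](C(=O)Nc4cccc(C(=O)O)c4)C3)[C@H](C)[C@H]12` and compound 2 `CCOC(=O)OCOC(=O)C1=C(S[C@@H]2CN[C@H](C(=O)Nc3cccc(C(=O)O)c3)C2)[C@H](C)[C@@H]2[C@@H]([C@@H](C)O)C(=O)N12` share one core and differ only in that compound 2 carries (ethoxycarbonyl)oxy in place of trifluoromethyl on a saturated chain carbon bound to an oxygen next to a carbonyl group. In an ADME assay for metabolic stability, read by LC-MS, with a stated time of 3 h, at pH 6.5, tested at 50 uM (a lower number here means that less of the compound is left, a higher number that more of the compound is left), compound 1 reaches a limit of the assay, > 95%. In this assay compound 2 likewise reaches a limit of the assay, > 95%. The step that the two limits leave unreadable from compound 1 to compound 2 thus cannot be read, since both of its ends sit at the limit of > 95% in this assay, at which 2 of the 2 values shown sit. Compound 2 therefore stands at the upper limit of the assay, not at a number.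

Compound 3 `COC(=O)OCOC(=O)C1=C(S[C@@H]2CN[C@H](C(=O)Nc3cccc(C(=O)O)c3)C2)[C@H](C)[C@@H]2[C@@H]([C@@H](C)O)C(=O)N12` differs from compound 2 by hydrogen in place of methyl on a saturated chain carbon bound to an oxygen next to a carbonyl group; cut one bond further out, the change reads ethoxycarbonyl to methoxycarbonyl. Among the compounds with values here, no measured step bears on this change, and the only measured step in this assay is unreadable. The step that the limit leaves unreadable from compound 2 to compound 3 is expected to be none beyond the scatter. Compound 3 is accordingly estimated at 96%, within a range from 85% to 100%, most likely again reported only as a limit.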

Compound 3, percent of the compound remaining: > 95%
Compound 3 ended at the assay's limit (the forecaster's own chance of this, stated with the estimate: 80%); the middle value lies beyond the limit too.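

Neither step to compound 3, from compound 1 or from compound 2, can be read in this assay, because all three compounds sit at one limit of the assay: the limit of > 95% in this assay, at which 3 of the 3 values shown sit.

The compounds shown leave open how far these three differ in the percent of compound remaining, and whether swapping these groups changes it at all.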